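The compounds below may be only part of what the source reports. "The series", "measured", "known", "first", "only" and "open" are said of these compounds alone.

Working notes on the series. Compound 1 `CNC(=O)N1CCCc2ccc(NC(=O)c3ccc(-c4cnn(C)c4)cc3)cc21` gives 77.4% in a functional assay on MV4-11 cells (Homo sapiens) for antiproliferative activity, with a stated time of 6 days, tested at 1.56 uM (a lower number here means a weaker effect, a higher number a stronger effect of the compound at the concentration tested), the highest of the three numbers recorded. Compound 3 `CNC(=O)N1CCCc2ccc(NC(=O)c3cccc(-c4cc[nH]n4)c3)cc21` gives 27.3%, and compound 2 `CNC(=O)N1CCCc2ccc(NC(=O)c3cccc(-c4ccn(S(C)(=O)=O)n4)c3)cc21` gives 4.03%. Compound 4 `CNC(=O)N1CCCc2ccc(NC(=O)c3ccc(-c4ccn(S(C)(=O)=O)n4)cc3)cc21` is not yet measured; it differs from compound 1 by 1-(methylsulfonyl)-1H-pyrazol-3-yl in place of 1-methyl-1H-pyrazol-4-yl on an aromatic carbon. Among the compounds with values here, the only measured step that bears on this is the removal of the methylsulfonyl group, a number 23.3 percentage points higher from compound 2 to compound 3 (beyond the scatter); the reverse direction, which compound 4 takes, should therefore cost activity. Compound 4 is expected to fall clearly in this assay, by about a number 47.4 percentage points lower from compound 1 to compound 4 (beyond the scatter), because compound 2 carrying the same methylsulfonyl group gives 4.03%. The estimate for compound 4 is 30%, within 5% to 65%.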

Compound 4, a percentage reported as inhibition, at one concentration (the size of the read-out at that concentration, not a potency): 8.81%
Compound 4: middle estimate off by 21.2 percentage points, on the high side; low and high end bracket the measured number.
By their numbers in this assay, from the lowest: compounds 2 and 4 (each within the scatter of the next); then compound 3; then compound 1.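

At this position, para to a large group, the swap to 1-(methylsulfonyl)-1H-pyrazol-3-yl carries a heavy cost in this assay, with a number 68.6 percentage points lower from compound 1 to compound 4 (beyond the scatter), a larger change than the earlier step on the methylsulfonyl group. The swap alters the group on the pyrazole nitrogen and the point of attachment of the pyrazole together, so this step cannot separate the two. Nothing measured here gives a reason for the loss. Still open, from the compounds shown here alone, is how an acetyl group or a longer alkyl chain on the pyrazole nitrogen would read here. Also open, going by these compounds, is how much of the step belongs to the point of attachment alone.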